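A Second Methyl on the Ring of Compound 2

A few compounds are considered here, and "the series" means these few. Any claim that something is new, unique, unknown or untested is made for them only; others in the source may bear on it.

In an assay on V79 cells for inhibition of cytochrome P450 11B2, mitochondrial (Homo sapiens), read by HTRF, with a stated time of 1 h (a lower number here means a stronger inhibitor, a higher number a weaker inhibitor), compound 1 `Fc1ccc2nc(-c3cccnc3)[nH]c2c1` gives only a limit, > 10000 nM, and not a number. Compound 2 `Cc1ccncc1-c1nc2cc(F)c(F)cc2n1C1CC1` gives 10.2 nM in this assay. Compound 2 thus holds the only real number among the two results shown. The other result, for compound 1, is the limit of > 10000 nM in this assay, at which 1 of the 2 values shown sits. Compound 3 `Cc1cncc(-c2nc3cc(F)c(F)cc3n2C2CC2)c1C` differs from compound 2 by methyl in place of hydrogen on an aromatic carbon. Among the measured compounds shown here, no measured step of this kind is available, so the change is expected to move potency little, a step of a 1.5-fold higher number from compound 2 to compound 3 (0.17 log units; within the scatter) within the scatter. Compound 3 is therefore estimated at 15 nM, in the range 5 nM to 45 nM.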

Compound 3, half-maximal inhibitory concentration: 0.2 nM
Estimate against measurement, compound 3: 75-fold (1.88 log units) above; the measured number lies below the stated range.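

In this assay a single added methyl on an aromatic carbon, two atoms from the ring nitrogen and ortho to a methyl group, gives a 51-fold lower number from compound 2 to compound 3 (1.71 log units; beyond the scatter). This position on the ring is therefore far from silent: one extra carbon atom here changes the number strongly, which compound 1 and compound 2 alone could not show. Nothing shown here explains why the step is so large.

As far as these compounds go, whether an ethyl or an amine at this position would keep the gain stays open. So does whether a methyl here needs the neighbouring methyl of compound 2 to have this effect.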